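This account rests on a few compounds, and the source may have more. Where it says the series, first, only, none or still open, it means among the compounds named here.

Among the measured compounds shown here, in a functional assay on HaCaT cells (Homo sapiens) for antiproliferative activity, read by sulforhodamine B assay, with a stated time of 3 days (on this read-out higher numbers stand for weaker inhibition and lower numbers for stronger inhibition), compound 1 (`CCOc1ccc(OC)c(CCc2ccc(O)c(C(=O)OC)c2)c1`) gives 540 nM and compound 2 (`COC(=O)c1cc(CCc2cc(SC)ccc2OC)ccc1O`) gives 860 nM as the upper of only two values, though the two lie within the scatter of each other. Compound 3 (`COC(=O)c1cc(CCc2cc(N(C)C)ccc2OC)ccc1O`) has dimethylamino in place of methylsulfanyl on an aromatic carbon, para to a methoxy group (dimethylamino in place of methylsulfanyl on an aromatic carbon). For the measured compounds named here, one measured step bears on this place: methylsulfanyl in place of ethoxy on an aromatic carbon (a 1.6-fold higher number from compound 1 to compound 2 (0.20 log units; within the scatter)), which stays within the scatter. Going by the values given here, a single step is thin evidence and no measured compound carries dimethylamino. Going by that step and by compound 2 (860 nM), no shift beyond the scatter is expected in this assay and the direction stays open. The expected step is small (a 1.1-fold lower number from compound 2 to compound 3 (0.03 log units; within the scatter)). The estimate for compound 3 is 800 nM (expected range 300 nM to 2100 nM).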

Compound 3, half-maximal inhibitory concentration: 920 nM
Beside the measured number, compound 3's estimate is 1.2-fold (0.06 log units) below it; low and high end bracket the measured number.
By their numbers in this assay, from the lowest: compounds 1, 2 and 3 (each within the scatter of the next).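

At the aromatic carbon para to a methoxy group, dimethylamino gives a third group at this place, and in this assay its step from methylsulfanyl stays within the scatter (a 1.1-fold higher number from compound 2 to compound 3 (0.03 log units; within the scatter)). The step from ethoxy also stays within the scatter (a 1.7-fold higher number from compound 1 to compound 3 (0.23 log units; within the scatter)), so none of the three groups separates from the others here, including the one that brings nitrogen to this position. No supporting measurement accounts for this lack of separation.

From the compounds shown here alone, it remains open whether a primary amine, a carboxylic acid or a longer chain at this place would give a step beyond the scatter. The compounds shown also leave open whether this lack of separation would hold if the methyl ester or the free hydroxyl on the other ring of the shared core were replaced by another group, such as an amide.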